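Swapping an amide-linked phenyl for a bromophenyl on the imine nitrogen

The source may report more compounds than this note shows. Statements on the series, on what has been measured and on what is new or still open speak of the compounds shown alone.

Compound 1 `O=C1Nc2ccc(S(=O)(=O)N3CCOCC3)cc2/C1=N/NC(=O)c1ccccc1` is tested in an ADME assay on WI-38 cells (Homo sapiens) for cytotoxicity, read by sulforhodamine B assay, with a stated time of 24 h (on this read-out lower numbers stand for stronger inhibition and higher numbers for weaker inhibition), where compound 1 gives 295000 nM, the lowest of the two numbers recorded. Its nearest neighbour, compound 2 `Cc1ccc(/N=C2\C(=O)Nc3ccc(S(=O)(=O)N4CCOCC4)cc32)cc1`, gives 309000 nM in this assay; the step of a 1.0-fold higher number from compound 1 to compound 2 (0.02 log units; within the scatter) lies within the scatter. Compound 3 `O=C1Nc2ccc(S(=O)(=O)N3CCOCC3)cc2/C1=N/c1ccc(Br)cc1` differs from compound 1 by 4-bromophenyl in place of benzamido on a double-bonded nitrogen. For the measured compounds named here, the one comparable step, the change from benzamido to an aryl group on that nitrogen, was a 1.0-fold higher number from compound 1 to compound 2 (0.02 log units; within the scatter), so no step beyond the scatter is expected here. Compound 3 is therefore estimated at 300000 nM in this assay, with a range from 150000 nM to 600000 nM, a step of a 1.0-fold higher number from compound 1 to compound 3 (0.01 log units; within the scatter).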

Compound 3, half-maximal inhibitory concentration: 372000 nM
Beside the measured number, compound 3's estimate is 1.2-fold (0.09 log units) below it; the measured number falls inside the stated range.
By their numbers in this assay, from the lowest: compounds 1, 2 and 3 (each within the scatter of the next).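

In this assay, 4-bromophenyl in place of benzamido on the double-bonded nitrogen stays within the scatter (a 1.3-fold higher number from compound 1 to compound 3 (0.10 log units; within the scatter)), and so does bromo in place of methyl on an aromatic carbon (a 1.2-fold higher number from compound 2 to compound 3 (0.08 log units; within the scatter)). Among these three compounds, then, a bromine on the aryl group changes the picture no more than the earlier swap did, and none of the steps goes beyond the scatter. No measurement shown offers an explanation for this.

Still open, as far as these compounds go, is whether an amine or a carboxylic acid in place of the bromo would move the number beyond the scatter. The same question stands for a longer chain on the double-bonded nitrogen.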